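This account rests on a few compounds, and the source may have more. Where it says the series, first, only, none or still open, it means among the compounds named here.

Two sulfonamides of the series have numbers in a functional assay on MIA PaCa-2 cells (Homo sapiens) for inhibition, read by MTT assay, with a stated time of 72 h; a lower number here means a stronger inhibitor of growth, a higher number a weaker inhibitor of growth. Compound 1 `Cc1ccc(C)c(S(=O)(=O)NCCCCCCNCc2ccc(Br)cc2)c1` gives 12000 nM in this assay, the lower of the two numbers. Compound 2 `CC(C)(C)c1ccc(CNCCNS(=O)(=O)c2cc(C(F)(F)F)cc(C(F)(F)F)c2)cc1` gives 15000 nM in this assay, within the scatter of compound 1. Compound 3 `COc1ccc(S(=O)(=O)NCCCCCCNCc2ccc(Br)cc2)cc1` differs from compound 1 at the sulfonyl group: 4-methoxyphenyl in place of 2,5-dimethylphenyl on a sulfonyl sulfur. Going by the values given here, no measured pair of the series shows such a swap, so no step size can be read from the data for it. The expected step of a 1.2-fold higher number from compound 1 to compound 3 (0.07 log units; within the scatter) is none beyond the scatter. Compound 3 is estimated at 14000 nM in this assay, with a range from 5000 nM to 40000 nM.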

Compound 3, concentration for 50% growth inhibition: 13000 nM
The estimate for compound 3 lay 1.1-fold (0.03 log units) above the measured number, and the stated range covers the measured number.
By their numbers in this assay, from the lowest: compounds 1, 3 and 2 (each within the scatter of the next).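

Going by these compounds alone, on the sulfonyl sulfur, 4-methoxyphenyl in place of 2,5-dimethylphenyl gives a 1.1-fold higher number from compound 1 to compound 3 (0.03 log units; within the scatter) in this assay, the first step that can be read. At this position, the two aryl groups, one with a hydrogen-bond acceptor and one without, cannot be told apart by this read-out. Nothing at hand gives a reason for this result. Open, going by these compounds, is whether a methyl group or a piperidine on the sulfonyl sulfur, or a carboxylic acid on the aryl ring, would give a step beyond the scatter. On these data alone, whether any change at this position can do so also remains open.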